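Carbamoyl for benzyl on the ring nitrogen of compound 1

The compounds below may be only part of what the source reports. "The series", "measured", "known", "first", "only" and "open" are said of these compounds alone.

Compound 1 `Cc1ccccc1CN1CCc2c(sc(NC(=O)c3ccccc3Cl)c2C(N)=O)C1` in a functional assay on HeLa cells (Homo sapiens) for antiproliferative activity, with a stated time of 24 h (a lower number here means a stronger inhibitor, a higher number a weaker inhibitor), gives > 50000 nM, which is a limit of the assay and not a number. Compound 2 `Cc1ccc(C(=O)Nc2sc3c(c2C(N)=O)CCN(Cc2c(Cl)cccc2Cl)C3)cc1` gives 47400 nM. Compound 3 `Cc1ccc(C(=O)Nc2sc3c(c2C(N)=O)CCN(Cc2ccc(Cl)cc2Cl)C3)cc1` gives > 50000 nM, again a limit of the assay. Going by the values given here, the single measured step, an at least 1.0-fold higher number from compound 2 to compound 3 (0.02 log units; that floor lies within the scatter), lies within the scatter, and the series clusters at the limit of > 50000 nM in this assay, at which 2 of the 3 values shown sit. The change to compound 4 `NC(=O)c1c(NC(=O)c2ccccc2Cl)sc2c1CCN(C(=O)Nc1ccccc1Cl)C2` is (2-chlorophenyl)carbamoyl in place of 2-methylbenzyl on an amine nitrogen in a ring. Among the compounds with values here, no measured step touches this position, so nothing measured points to a direction. With compound 1 at its limit and the rest flat, compound 4 is expected to stay near that limit. The step of a number no higher from compound 1 to compound 4 (the limit leaves the size open) is therefore expected to be none beyond the scatter. The estimate for compound 4 is 50000 nM, with a range from 20000 nM to 120000 nM.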

Compound 4, half-maximal inhibitory concentration: 45400 nM
Compound 4: the middle estimate sits 1.1-fold (0.04 log units) above what was measured; low and high end bracket the measured number.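

In this assay, going by these compounds alone, the first measured step at this position, an at least 1.1-fold lower number from compound 1 to compound 4 (0.04 log units; that floor lies within the scatter), gives no readable change, and the limit on compound 1 leaves its true size open. Replacing 2-methylbenzyl with (2-chlorophenyl)carbamoyl on the amine nitrogen in a ring adds a hydrogen-bond donor and a hydrogen-bond acceptor, yet compound 4 still gives no clear separation from the rest of the series, which remains bunched at the top of the range: the limit of > 50000 nM in this assay, at which 2 of the 4 values shown sit.

Still open, from the compounds shown here alone, is whether a group without an aromatic ring, such as a longer alkyl chain, a carboxylic acid or a free amine, on that ring nitrogen would bring the number clearly below this range.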